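The source may report more compounds than this note shows. Statements on the series, on what has been measured and on what is new or still open speak of the compounds shown alone.

Measured compounds:
compound 1 `CNc1nc(Nc2ccc(C)c([N+](=O)[O-])c2)ncc1C(=O)Nc1cc(NC(=O)c2ccc(OC)c(OC)c2)ccc1C`, 7300 nM
compound 2 `CNc1nc(Nc2ccc(C)c(N)c2)ncc1C(=O)Nc1cc(NC(=O)c2cccc(OC)c2)ccc1C`, > 10000 nM

Of the compounds shown here, two have been tested in an ADME assay on BaF3 cells (Mus musculus) for antiproliferative activity, read by CellTiter-Glo and CCK-8 assay, with a stated time of 72 h; a higher number here means a weaker inhibitor of growth, a lower number a stronger inhibitor of growth. Compound 1 gives 7300 nM, a weak result. Compound 2 is reported only as a limit of the limit of > 10000 nM in this assay, at which 1 of the 2 values shown sits, so no number is known for it. The two compounds differ in two places, and what their values show is only that both sit at the weak end of the scale.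

Compound 3 `CNc1nc(Nc2ccc(C)c(N)c2)ncc1C(=O)Nc1cc(NC(=O)c2ccc(OC)c(OC)c2)ccc1C` has not yet been tested in this assay. It differs from compound 2 in one place: methoxy in place of hydrogen on an aromatic carbon. Compound 1 already carries this second methoxy group and still gives only a weak result, so a large gain is not expected from the change alone. The step from compound 2 to compound 3 is expected to be a number no higher from compound 2 to compound 3 (the limit leaves the size open), either none beyond the scatter or a modest move toward stronger inhibition, with the real chance that the result is again reported only as a limit. Compound 3 is estimated at 10000 nM, within a range from 4000 nM to 25000 nM.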

Compound 3, concentration for 50% growth inhibition: > 10000 nM
Compound 3 ended at the assay's limit; the forecaster's own chance of this, stated with the estimate: 50%; the middle value sits exactly at the limit.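

In this assay compound 3 is reported only as a limit, > 10000 nM, so adding the second methoxy group, which turns 3-methoxyphenyl into 3,4-dimethoxyphenyl, does not bring this amino compound to a measurable value. The step between compound 2 and compound 3 cannot be read, since both ends are limits: the limit of > 10000 nM in this assay, at which 2 of the 3 values shown sit.

With the 3,4-dimethoxyphenyl group common to both compounds, amino in place of nitro on an aromatic carbon gives an at least 1.3-fold higher number from compound 1 to compound 3 (0.13 log units; that floor lies within the scatter), so this pair shows no firm loss, and the limit leaves the true size of the step open.

The compounds shown leave open whether the second methoxy group has any effect on the value when the nitro group is present. They also leave open whether a different group at this place on the ring, such as a hydroxyl, a fluorine or a longer ether chain, would bring the value away from the limit.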